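Oxadiazole to oxime ether on the shared core

This account rests on a few compounds, and the source may have more. Where it says the series, first, only, none or still open, it means among the compounds named here.

Compounds measured so far:
compound 1 `Cc1nc(-c2ccccc2NCC2=NCCN2)cs1`
compound 2 `Cc1noc(-c2ccccc2NCC2=NCCN2)n1`
Not yet measured:
compound 3 `CC/C(=N/OC)c1ccccc1NCC1=NCCN1`

In a functional assay for activation of Alpha-1D adrenergic receptor (Homo sapiens) (a higher number here means that more compound is needed for the effect, a lower number that less compound is needed), compound 1 gives only a limit, < 5020 nM. In this assay compound 2 likewise gives only a limit, < 5020 nM. The step that the two limits leave unreadable from compound 1 to compound 2 is therefore not readable, and the limit of < 5020 nM in this assay, at which 2 of the 2 values shown sit, is all the evidence on measured steps. Compound 2 stands at that limit and nowhere more exact. The change to compound 3 is a group of 6 heavy atoms (4 carbon, 1 nitrogen, 1 oxygen; no ring) in place of a group of 6 heavy atoms (3 carbon, 2 nitrogen, 1 oxygen; one five-membered aromatic ring with 3 hetero atoms), on an aromatic carbon. Going by the values given here, no measured step bears on it, so no step beyond the scatter is expected in this assay. Compound 3 is expected near 1500 nM, ranging from 200 nM to 5000 nM. The expected step is a step that the limit leaves unreadable from compound 2 to compound 3.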

Compound 3, half-maximal effective concentration: < 5020 nM
Compound 3: only a limit was reported; the forecaster's own chance of this, stated with the estimate: 40%; the middle value is on the limit's open side.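

Going by these compounds alone, no step among compound 1, compound 2 and compound 3 can be read in this assay, since all three rest on one limit: the limit of < 5020 nM in this assay, at which 3 of the 3 values shown sit. The compounds shown leave open the exact value of each, and whether exchanging the group on the aromatic carbon shifts it at all.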